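The source may hold more compounds than are shown below. What is called first, only, known or untested is meant among the compounds shown, and "the series" means these compounds.

Measured compounds:
compound 1, `COC(=O)c1cc(-n2c(-c3ccccc3)cc3c2CCCC3)ccc1O`, in a functional assay on the whole organism (strain Wistar) for inhibition, with Rattus norvegicus as the target, read by paw edema, with stated times of 30 min and 3 h, at a dose of 200 mg/kg by the oral route; a lower number here means less inhibition, a higher number more inhibition at the dose given (going by the name of the read-out): 0%
compound 2, `COc1ccc(-c2cc3c(n2-c2ccc(O)c(C(=O)O)c2)CCCC3)cc1`, in this assay: 50%

Of the two numbers, compound 2 stands highest in this assay; its nearest neighbour is compound 1, whose value lies lower by a gap beyond the scatter. Among the compounds with values here, the two differ in more than one place, so no single step between them can be named.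

Compound 3, `O=C(O)c1cc(-n2c(-c3ccc(O)cc3)cc3c2CCCC3)ccc1O`, has not yet been measured. It differs from compound 2 in one place only: hydrogen in place of methyl on an oxygen on an aromatic ring. Within the data shown here, no pair of measured compounds differing by the same change is available, so the size of that step rests on no measurement. The change is small in what is counted, and a step within the scatter, or a modest one in either direction, is what is expected in this assay.

Accordingly, compound 3 is expected to give about 42%, within 15% to 65%, an estimated step of a number 8 percentage points lower from compound 2 to compound 3 (within the scatter).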

Compound 3, a percentage reported as inhibition, in the whole organism at one dose (the size of the read-out at that dose, not a potency): 20%
Beside the measured number, compound 3's estimate is 22 percentage points above it, within the range that was stated.
By their numbers in this assay, from the lowest: compound 1; then compound 3; then compound 2.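

Within the data shown here, the change from 4-methoxyphenyl to 4-hydroxyphenyl gives the first single step that can be read in this assay, and the step is a number 30 percentage points lower from compound 2 to compound 3 (beyond the scatter) and so is not lost in the usual spread of repeat measurements. The methyl on this oxygen therefore matters in this series at the dose given, although compound 3, with its free hydroxy, still shows 20% of inhibition. No accompanying measurement bears on why the step takes this size.

On these data alone, whether a longer chain such as ethoxy on the same oxygen, or an amine or a fluorine in its place, would stand nearer to compound 2 or to compound 3 remains open. With a single dose read, the compounds also leave open whether this step would keep its size at other doses.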